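The source may report more compounds than this note shows. Statements on the series, on what has been measured and on what is new or still open speak of the compounds shown alone.

In an ADME assay on HEK293 cells (Homo sapiens) for cytotoxicity, read by resazurin assay, with a stated time of 72 h (a lower number here means that less compound is tolerated, a higher number that more compound is tolerated), compound 1 `CCc1cccc(CNC(=O)c2nc3cccc(COCc4ccc(C(=O)O)cc4)c3c(=O)[nH]2)c1` gives > 40000 nM, which is a limit and not a number. Compound 2 `CCc1cccc(CNC(=O)c2nc3ccc(Cl)c(COCc4ccc(C(=O)O)cc4)c3c(=O)[nH]2)c1` gives > 20000 nM, also a limit. Compound 3 `CCc1cccc(CNC(=O)c2nc3c(F)ccc(COCc4ccc(C(=O)O)cc4)c3c(=O)[nH]2)c1` gives > 20000 nM, again a limit. Compound 4 `O=C(O)c1ccc(COCc2cccc3nc(C(=O)NCc4ccccc4)[nH]c(=O)c23)cc1` has not yet been measured. It turns 3-ethylbenzyl into benzyl, with hydrogen in place of ethyl on an aromatic carbon, meta to a large group: hydrogen in place of ethyl on an aromatic carbon. Two measured steps are the nearest guide, though neither touches the ethyl group. One is a step that the two limits leave unreadable from compound 1 to compound 2, and the other is a step that the two limits leave unreadable from compound 1 to compound 3. Neither gives a size, so no clear move in this assay is expected, and the estimated change is a number no higher from compound 1 to compound 4 (the limit leaves the size open). For compound 4 the estimated value is 40000 nM, with an expected range of 20000 nM to 80000 nM.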

Compound 4, half-maximal cytotoxic concentration: > 20000 nM
Compound 4: a limit, no number (the forecaster's own chance of this, stated with the estimate: 90%); the middle value is on the limit's open side.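

Compound 1 and compound 4 each give only a limit in this assay, and no step can be read between them. The actual half-maximal cytotoxic concentration of each compound shown stays open, as does whether hydrogen in place of ethyl changes it.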